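Swapping an Aromatic Methoxy for Propyl in Pyrrolidine Amides

The source may report more compounds than this note shows. Statements on the series, on what has been measured and on what is new or still open speak of the compounds shown alone.

Measured so far:
compound 1, `O=C(CCCCCCc1cccc(Cl)c1)N1CCCC1`, 3700 nM
compound 2, `COc1cccc(CCCCCCC(=O)N2CCCC2)c1`, > 100000 nM

Two compounds share the same core and differ only in one group on the aromatic ring. In an assay on HEK293 cells for inhibition of N-acylethanolamine-hydrolyzing acid amidase (Rattus norvegicus), read by LC-MS, with a stated time of 30 min (on this read-out higher numbers stand for weaker inhibition and lower numbers for stronger inhibition), compound 1 gives 3700 nM. For compound 2 the assay reports only a limit, > 100000 nM, not a number. Going by the values given here, the one measured step, an at least 27-fold higher number from compound 1 to compound 2 (1.43 log units; beyond the scatter), was therefore large and went toward weaker inhibition, though its true size is hidden by the limit of > 100000 nM in this assay, at which 1 of the 2 values shown sits. On the numbers shown, compound 2 thus stands at the weak end, at the assay limit.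

Compound 3, `CCCc1cccc(CCCCCCC(=O)N2CCCC2)c1`, is the next step: propyl in place of methoxy on an aromatic carbon. The methoxy that arrived in the weakening step leaves again, and a propyl chain takes its place. Among the compounds with values here, the only step that bears on this is the one from compound 1 to compound 2, which shows that removing methoxy could recover a good deal of inhibition, although propyl is not chloro, so the outcome is uncertain.

The step of an at least 8.3-fold lower number from compound 2 to compound 3 (0.92 log units; beyond the scatter) is expected, with a real chance that compound 3 again sits at the limit. For compound 3 the estimate is 12000 nM, within 2500 nM to 80000 nM.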

Compound 3, half-maximal inhibitory concentration: > 100000 nM
Compound 3 ended at the assay's limit; the forecaster's own chance of this, stated with the estimate: 25%; middle value at least 8.3-fold (0.92 log units) from the limit.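

Compound 3 shows that removing the methoxy does not by itself restore inhibition in this assay: replacing chloro with propyl gives an at least 27-fold higher number from compound 1 to compound 3 (1.43 log units; beyond the scatter). Two different groups at this ring position, methoxy with its oxygen and propyl with carbon only, have now both taken inhibition out of the range this test can put a number on, so among the three compounds only the chloro compound, compound 1, gives a measured value. The step from compound 2 to compound 3 cannot be read, and methoxy and propyl cannot be ranked against each other, because of what the test can report: the limit of > 100000 nM in this assay, at which 2 of the 3 values shown sit.

On these data alone, it remains open whether other groups at this position, such as fluoro, bromo or methyl, would keep or improve on the inhibition of compound 1. Also open are how much weaker compound 2 and compound 3 truly are and whether either group would behave the same way elsewhere on the ring, since the compounds shown carry each group at this one position only.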